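The source may report more compounds than this note shows. Statements on the series, on what has been measured and on what is new or still open speak of the compounds shown alone.

Two measured compounds share one core and differ only in the chain hanging from the carbon that is double-bonded to nitrogen. Compound 1 `CC(C)=NNc1nc(-c2cccc([N+](=O)[O-])c2)cs1` carries a methyl there, and in an assay on isolated protein for inhibition of Amine oxidase [flavin-containing] B (Homo sapiens), read by fluorescence, with a stated time of 20 min (on this read-out lower numbers stand for stronger inhibition and higher numbers for weaker inhibition), compound 1 gives 716 nM. Compound 2 `CC/C(C)=N\Nc1nc(-c2cccc([N+](=O)[O-])c2)cs1` carries an ethyl instead, and in this assay compound 2 gives 351 nM, the lowest of the two numbers. Among the measured compounds shown here, the step of a 2.0-fold lower number from compound 1 to compound 2 (0.31 log units; beyond the scatter) is the only comparison available. Compound 3 `CCC/C(C)=N\Nc1nc(-c2cccc([N+](=O)[O-])c2)cs1` extends the same chain once more: methyl in place of hydrogen on a saturated chain carbon, two bonds along the chain from a carbon with a double bond to nitrogen. For the measured compounds named here, this lengthening is the same kind of change as the one from compound 1 to compound 2, only one bond further out, so that earlier step is the closest guide, though a change placed further along the chain need not repeat the same gain. A further modest lowering of the number in this assay, or no step beyond the scatter, is the expected outcome, and the estimated step for compound 3 is a 1.4-fold lower number from compound 2 to compound 3 (0.15 log units; within the scatter). In this assay compound 3 is therefore expected to give about 250 nM, with a likely range from 110 nM to 600 nM.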

Compound 3, half-maximal inhibitory concentration: 55 nM
Beside the measured number, compound 3's estimate is 4.5-fold (0.66 log units) above it; the measured number lies below the stated range.
By their numbers in this assay, from the lowest: compound 3; then compound 2; then compound 1.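

Going from ethyl to propyl at this position, in this assay, gives a 6.4-fold lower number from compound 2 to compound 3 (0.80 log units; beyond the scatter), a larger drop than the earlier methyl to ethyl change, which gave a 2.0-fold lower number from compound 1 to compound 2 (0.31 log units; beyond the scatter), so the gain from lengthening this chain does not shrink with this further extension and does not simply repeat the first step. Across the whole series, ethyl in place of hydrogen on the saturated chain carbon bound to the carbon with a double bond to nitrogen gives a 13-fold lower number from compound 1 to compound 3 (1.11 log units; beyond the scatter), and all three compounds follow the same order, with the number falling as the chain grows. Nothing available explains why the propyl chain brings the larger gain.

Three straight chains cannot show where this trend ends, so a butyl or a still longer chain might lower the number further, level off or reverse the gain. They also leave open whether length alone matters here, a question that a branched isopropyl group, or a chain ending in an amine or a carboxylic acid, could help to answer.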